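From 3-bromophenyl to 4-fluorophenyl in a weakly active set

The compounds below may be only part of what the source reports. "The series", "measured", "known", "first", "only" and "open" are said of these compounds alone.

In a functional assay on SGC-7901 cells (Homo sapiens) for antiproliferative activity, read by sulforhodamine B assay, with a stated time of 72 h (a lower number here means a stronger inhibitor, a higher number a weaker inhibitor), compound 1 (`COc1ccc(C)cc1NC(=S)N/N=C/c1ccc2ccccc2n1`) gives > 100000 nM as its reading, which is a limit of the assay and not a number. Compound 3 (`NC(=S)N/N=C/c1cnc2ccccc2n1`) gives > 100000 nM as its reading, again a limit and not a number. Within the data shown here, compound 2 (`S=C(N/N=C/c1ccc2ccccc2n1)Nc1cccc(Br)c1`) gives 78600 nM as the only actual number of the three. The rest of the picture is the limit of > 100000 nM in this assay, at which 2 of the 3 values shown sit, and nothing more, so compound 2 cannot be ranked against a measured neighbour.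

Compound 4 (`Fc1ccc(NC(=S)N/N=C/c2ccc3ccccc3n2)cc1`) has not yet been measured. It carries 4-fluorophenyl in place of 3-bromophenyl on an amide-type nitrogen. Among the measured compounds shown here, no measured pair shows what such an exchange does, so the expectation rests on compound 2 alone, at 78600 nM in this assay. The expected change, a 1.3-fold lower number from compound 2 to compound 4 (0.12 log units; within the scatter) in size, is none beyond the scatter. For compound 4 the estimated value is 60000 nM with an expected range from 15000 nM to 150000 nM in this measurement, and a reading at the limit would not be surprising.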

Compound 4, half-maximal inhibitory concentration: 32300 nM
The estimate for compound 4 lay 1.9-fold (0.27 log units) above the measured number; the measured number falls inside the stated range.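

The exchange of 3-bromophenyl for 4-fluorophenyl on the amide-type nitrogen gives, in this assay, a 2.4-fold lower number from compound 2 to compound 4 (0.39 log units; beyond the scatter). Among these compounds, this is the first measured step in the set, and it shows that the aryl group at this place can shift the reading beyond the scatter, though only modestly. Compound 2 no longer stands alone as a number, yet the other readings give nothing further to rank it against: the limit of > 100000 nM in this assay, at which 2 of the 4 values shown sit.

In this one step the halogen and its ring position change together, so the compounds shown cannot separate the two; 3-fluorophenyl or 4-bromophenyl on the same nitrogen would be needed for that. They also leave open how a non-halogen group, such as an aminophenyl or a carboxyphenyl group, would read at this place.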